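This account rests on a few compounds, and the source may have more. Where it says the series, first, only, none or still open, it means among the compounds named here.

Compound 1 `COc1ccc(/C=C/C(=O)c2ccc(OC)c3c2OC(C)(C)C=C3)c(F)c1` is the starting point of this step. In a functional assay on HT-29 cells (Homo sapiens) for antiproliferative activity, read by MTT assay, with a stated time of 24 h (a lower number here means a stronger inhibitor, a higher number a weaker inhibitor), compound 1 gives > 10000 nM, which is a limit of the assay rather than a number. Compound 1 therefore sits at the limit of > 10000 nM in this assay, at which 1 of the 3 values shown sits, so only a bound is known for it. Compound 2 `CCN(CC)c1ccc(/C=C/C(=O)c2ccc(OC)c3c2OC(C)(C)C=C3)cc1` gives 550 nM in this assay, and compound 3 `COc1ccc(C(=O)/C=C/c2ccccn2)c2c1C=CC(C)(C)O2` gives 2120 nM in this assay. For the measured compounds named here, the one step that starts from compound 1 and changes the same place is an at least 4.7-fold lower number from compound 1 to compound 3 (0.67 log units; beyond the scatter). Compound 4 `COc1ccc(C(=O)/C=C/c2ccc(Cl)cc2)c2c1C=CC(C)(C)O2` has not yet been measured. It differs from compound 1 as follows: 4-chlorophenyl in place of 2-fluoro-4-methoxyphenyl on a double-bonded chain carbon bound to a double-bonded chain carbon. The change to compound 4 touches the same place as the step to compound 3, and that step moved the number down from a limit by at least a modest amount. A step downward into the measurable range is expected here too, since compound 1 sits at the limit of > 10000 nM in this assay, at which 1 of the 3 values shown sits; its size is uncertain, as the starting value is only a bound. The step expected for compound 4 is an at least 3.3-fold lower number from compound 1 to compound 4 (0.52 log units; beyond the scatter) in this assay. Compound 4 is estimated at 3000 nM in this assay, with a range from 800 nM to 12000 nM.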

Compound 4, half-maximal inhibitory concentration: > 10000 nM
Compound 4: a limit, no number (the forecaster's own chance of this, stated with the estimate: 25%); middle value at least 3.3-fold (0.52 log units) from the limit.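

In this assay compound 4 gives > 10000 nM, a limit of the assay and not a number, and the step that links it to compound 1 cannot be read. The drop into the measurable range seen with pyridin-2-yl therefore does not extend to every replacement of 2-fluoro-4-methoxyphenyl at this place: 4-chlorophenyl in place of pyridin-2-yl gives an at least 4.7-fold higher number from compound 3 to compound 4 (0.67 log units; beyond the scatter), and chloro in place of diethylamino on an aromatic carbon gives an at least 18-fold higher number from compound 2 to compound 4 (1.25 log units; beyond the scatter). Among these four compounds, the two with a readable number carry a nitrogen in this group, as diethylamino or as the pyridine ring, and the two without one carry none, a pattern that rests on few compounds and on limits: the limit of > 10000 nM in this assay, at which 2 of the 4 values shown sit.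

As far as these compounds go, how far compound 1 and compound 4 lie beyond the limit remains open, as does whether the nitrogen itself or some other feature of these groups separates the two pairs. An unsubstituted phenyl, a 4-aminophenyl, a 4-dimethylaminophenyl or a pyridin-3-yl group at the same place would help to separate these readings.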